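Ring substituent swaps at the saturated carbon

A few compounds are considered here, and "the series" means these few. Any claim that something is new, unique, unknown or untested is made for them only; others in the source may bear on it.

Three compounds share one core and differ only in the group on a saturated ring carbon. Compound 1 `COc1ccccc1C1C(C#N)=C(N)N(c2ccc(S(N)(=O)=O)cc2)C2=C1C(=O)CCC2` gives 0% in a functional assay on Ehrlich cells (Mus musculus) for antiproliferative activity, read by trypan blue exclusion, with a stated time of 2 h, tested at 25 ug/mL; on this read-out higher numbers stand for a stronger effect at the one concentration tested and lower numbers for a weaker effect. Compound 2 `COc1ccc(C2C(C#N)=C(N)N(c3ccc(S(N)(=O)=O)cc3)C3=C2C(=O)CCC3)cc1` gives 50% in this assay, and compound 3 `COc1cc(CC2C(C#N)=C(N)N(c3ccc(S(N)(=O)=O)cc3)C3=C2C(=O)CCC3)ccc1O` gives 50% in the same assay. The steps are large where the 2-methoxyphenyl compound is involved: a number 50 percentage points higher from compound 1 to compound 2 (beyond the scatter) and a number 50 percentage points higher from compound 1 to compound 3 (beyond the scatter). Between the other two there is nothing: no change at the digits printed from compound 2 to compound 3 (within the scatter). Compound 3 thus stands level with compound 2 at the digits reported, the two together at the top of the three numbers, with compound 1 as the only clear outlier below.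

Compound 4 `N#CC1=C(N)N(c2ccc(S(N)(=O)=O)cc2)C2=C(C(=O)CCC2)C1c1cccc([N+](=O)[O-])c1` is the next member. Its change from compound 3 is 3-nitrophenyl in place of 4-hydroxy-3-methoxybenzyl on a saturated ring carbon. Going by the values given here, the step that bears most directly is the one from compound 2 to compound 3, which showed no change, yet the steps from compound 1 show that this position can move the read-out by a large amount in either direction. Among the compounds with values here, no measured step covers a nitro group, so the direction is open. The working expectation for compound 4 is a value in this assay near the level of compound 3, 40%, with a wide range from 0% to 75%, which corresponds to an estimated step of a number 10 percentage points lower from compound 3 to compound 4 (within the scatter).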

Compound 4, a percentage reported as activity, at one concentration (the size of the read-out at that concentration, not a potency): 50%
For compound 4 the middle estimate is 10 percentage points below the measured one; measured number inside the range.
By their numbers in this assay, from the lowest: compound 1; then compounds 2, 3 and 4 (each within the scatter of the next).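

In this assay, 3-nitrophenyl in place of 4-hydroxy-3-methoxybenzyl on this saturated ring carbon gives no change at the digits printed from compound 3 to compound 4 (within the scatter), and 3-nitrophenyl in place of 4-methoxyphenyl gives no change at the digits printed from compound 2 to compound 4 (within the scatter), so the level shared by compound 2 and compound 3 also holds for a nitro-bearing phenyl group that has neither methoxy nor hydroxy. Against 2-methoxyphenyl, the same group gives a number 50 percentage points higher from compound 1 to compound 4 (beyond the scatter), which leaves compound 1 as the only one of the four apart from the others and the exception to an otherwise level set. The compounds shown offer no information on why the three groups read alike or why compound 1 differs.

On these data alone, whether the low value of compound 1 goes with a group on the 2-position of the phenyl ring in general stays open, and 2-nitrophenyl or 2-aminophenyl at this carbon would bear on that, as would an unsubstituted phenyl or a carboxylic acid on the ring for the wider tolerance of this position. With a single concentration behind each value, whether compound 2, compound 3 and compound 4 would show a stronger or weaker effect at any other concentration also remains unresolved.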